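Bromo in place of methyl in the ethyl compounds

The source may report more compounds than this note shows. Statements on the series, on what has been measured and on what is new or still open speak of the compounds shown alone.

Measured in a functional assay on 4T1 cells (Homo sapiens) for cytotoxicity, read by MTT assay, with a stated time of 48 h; on this read-out higher numbers stand for weaker inhibition and lower numbers for stronger inhibition:
Compound 1 `CC(C)n1c(/C=C2/C(=O)Nc3ccc(Br)cc32)nc2ccccc21`: 5960 nM.
Compound 2 `CCn1c(/C=C2/C(=O)Nc3ccc(F)cc32)nc2ccccc21`: > 50000 nM.
Compound 3 `CCn1c(/C=C2/C(=O)Nc3ccc(C)cc32)nc2ccccc21`: 39400 nM.

For compound 2, > 50000 nM is a limit and not a number. Of the two true numbers, compound 3 holds the higher at 39400 nM, and the lower, from compound 1, lies beyond the scatter from it.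

Compound 4 `CCn1c(/C=C2/C(=O)Nc3ccc(Br)cc32)nc2ccccc21` is unmeasured and carries bromo in place of methyl on an aromatic carbon. Going by the values given here, the one measured step at that carbon, an at least 1.2-fold lower number from compound 2 to compound 3 (0.10 log units; that floor lies within the scatter), rests on the limit and gives little guide to size. Among the compounds with values here, compound 1, the only bromo compound measured, gives 5960 nM, which suggests a lower number. The expected move in this assay is a 3.0-fold lower number from compound 3 to compound 4 (0.48 log units; beyond the scatter), towards stronger inhibition. The estimate for compound 4 is 13000 nM, with an expected range of 5000 nM to 35000 nM.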

Compound 4, half-maximal inhibitory concentration: 40700 nM
For compound 4 the middle estimate is 3.1-fold (0.50 log units) below the measured one; measured number above the stated range.
By their numbers in this assay, from the lowest: compound 1; then compounds 3 and 4 (each within the scatter of the next). At a limit, above all of these: compound 2.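

Bromo in place of methyl on the aromatic carbon in the ethyl compounds gives a 1.0-fold higher number from compound 3 to compound 4 (0.01 log units; within the scatter) and does not separate the two. The bromo compounds place the difference on the chain instead, with a 6.8-fold higher number from compound 1 to compound 4 (0.83 log units; beyond the scatter), for hydrogen in place of methyl on the saturated chain carbon bound to the aromatic nitrogen. Bromo in place of fluoro at that aromatic carbon gives only a floor, an at least 1.2-fold lower number from compound 2 to compound 4 (0.08 log units; that floor lies within the scatter). Compound 2 carries a limit and not a number: the limit of > 50000 nM in this assay, at which 1 of the 4 values shown sits.

Open, as far as these compounds go, is whether the same chain change holds with methyl on the aromatic carbon. Also open, from the compounds shown here alone, is how an amine or a carboxylic acid at that carbon would read.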